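Changing the Amine Chain: From Pyrrolidine to Methylpiperazine

The source may hold more compounds than are shown below. What is called first, only, known or untested is meant among the compounds shown, and "the series" means these compounds.

- compound 1 `O=C1c2c[n+]([O-])c3ccccc3c2C(=O)c2c1c1ccccc1n2Cc1cn(C[C@H](O)CO)nn1`: 1130 nM
- compound 2 `O=C1c2c[n+]([O-])c3ccccc3c2C(=O)c2c1c1ccccc1n2CCN1CCCC1`: 930 nM
- compound 3 `CC1(C)O[C@@H](CO)[C@H](Cn2cc(Cn3c4c(c5ccccc53)C(=O)c3c[n+]([O-])c5ccccc5c3C4=O)nn2)O1`: 500 nM

These three compounds share a core and differ in the chain carried on an aromatic nitrogen. All were tested in a toxicity assay on L02 cells (Homo sapiens) for cytotoxicity, read by MTT assay, with a stated time of 72 h; a higher number here means a weaker inhibitor, a lower number a stronger inhibitor. Compound 2 gives the middle of the three numbers, but it lies within the scatter of both compound 1 and compound 3.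

The next compound, compound 4 `CN1CCN(CCCn2c3c(c4ccccc42)C(=O)c2c[n+]([O-])c4ccccc4c2C3=O)CC1`, has not yet been measured. Its change from compound 2 is (4-methylpiperazin-1-yl)methyl in place of pyrrolidin-1-yl on a saturated chain carbon, two bonds along the chain from an aromatic nitrogen. Cut one bond further out, this reads 2-(pyrrolidin-1-yl)ethyl to 3-(4-methylpiperazin-1-yl)propyl.

Two measured chain changes offer a rough guide: a 1.2-fold lower number from compound 1 to compound 2 (0.08 log units; within the scatter), and a 2.3-fold lower number from compound 1 to compound 3 (0.35 log units; beyond the scatter). Neither introduces this piperazine group, so they suggest only the likely size of the step, not its direction. No step beyond the scatter is therefore expected in this assay, and the estimated step is a 1.2-fold lower number from compound 2 to compound 4 (0.07 log units; within the scatter). For compound 4 the estimated value is 800 nM, with an expected range of 300 nM to 2000 nM.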

Compound 4, half-maximal inhibitory concentration: 230 nM
The estimate for compound 4 lay 3.5-fold (0.54 log units) above the measured number; measured number outside the range, below it.
By their numbers in this assay, from the lowest: compound 4; then compounds 3, 2 and 1 (each within the scatter of the next, the first and the last beyond it).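

In this assay, going from 2-(pyrrolidin-1-yl)ethyl to 3-(4-methylpiperazin-1-yl)propyl gives a 4.0-fold lower number from compound 2 to compound 4 (0.61 log units; beyond the scatter) and so moves the number beyond the scatter, whereas the earlier swap of the triazole chain for the pyrrolidine chain gave only a 1.2-fold lower number from compound 1 to compound 2 (0.08 log units; within the scatter) and stayed within it. The chain on the aromatic nitrogen can therefore shift this number by more than repeat measurements would, and against the triazole chain the new chain gives a 4.9-fold lower number from compound 1 to compound 4 (0.69 log units; beyond the scatter) as a larger step still. Compound 4 and compound 3 remain within the scatter of each other, so no single chain stands apart from all the others.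

From the compounds shown here alone, the ring and the chain length change together in this step, so it stays open which of them matters; a 3-(pyrrolidin-1-yl)propyl chain or a 2-(4-methylpiperazin-1-yl)ethyl chain would separate the two. Nothing given here offers an explanation for the step.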